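The source may hold more compounds than are shown below. What is called first, only, known or untested is meant among the compounds shown, and "the series" means these compounds.

In a functional assay on MCF7 cells (Homo sapiens) for antiproliferative activity (a higher number here means a weaker inhibitor, a lower number a stronger inhibitor), compound 1 `O=C(Nc1ccc(O)c2c(=O)cc(-c3ccccc3Cl)oc12)c1ccc(Cl)c(Cl)c1` gives 15000 nM, compound 2 `Cc1ccc(C(=O)Nc2ccc(O)c3c(=O)cc(-c4ccccc4Cl)oc23)cc1` gives 10000 nM, and compound 3 `C[C@@H](NC(=O)OC(C)(C)C)C(=O)Nc1ccc(O)c2c(=O)cc(-c3ccccc3Cl)oc12` gives 5500 nM. Compound 3 is clearly separated only from compound 1: a 2.7-fold lower number from compound 1 to compound 3 (0.44 log units; beyond the scatter) is modest but beyond the scatter, whereas a 1.8-fold lower number from compound 2 to compound 3 (0.26 log units; within the scatter) stays within it. Compound 4 `CCC(C)OC(=O)Nc1ccc(O)c2c(=O)cc(-c3ccccc3Cl)oc12` has sec-butoxy in place of 1-((tert-butoxycarbonyl)amino)ethyl on a carbonyl carbon. Those two steps and a 1.5-fold lower number from compound 1 to compound 2 (0.18 log units; within the scatter) all swap the group on a carbonyl carbon, and all are small. None of them introduces sec-butoxy, so they give no clear direction, and no step beyond the scatter is expected in this assay. The expected change is a 1.5-fold higher number from compound 3 to compound 4 (0.16 log units; within the scatter). For compound 4 the estimated value is 8000 nM, with an expected range of 3000 nM to 20000 nM.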

Compound 4, half-maximal inhibitory concentration: 30000 nM
Compound 4: middle estimate off by 3.8-fold (0.57 log units), on the low side, and the stated range ends below it.
By their numbers in this assay, from the lowest: compounds 3, 2, 1 and 4 (each within the scatter of the next, the first and the last beyond it).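

In this assay, going by these compounds alone, the group on this carbonyl carbon matters more than the earlier compounds showed: sec-butoxy gives the first clear rise (a 5.5-fold higher number from compound 3 to compound 4 (0.74 log units; beyond the scatter); a 3.0-fold higher number from compound 2 to compound 4 (0.48 log units; beyond the scatter)). Against the 3,4-dichlorophenyl group there is no such separation (a 2.0-fold higher number from compound 1 to compound 4 (0.30 log units; within the scatter)), so compound 1 and compound 4 cannot be ordered. Nothing available explains these differences.

Going by these compounds, whether the rise follows the oxygen attached to the carbonyl carbon or the sec-butyl chain itself remains open. On these data alone, how a free amine in place of the 1-((tert-butoxycarbonyl)amino)ethyl group's protected nitrogen would compare is also open.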